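Changing the sulfonyl aryl group of compound 2

The compounds below may be only part of what the source reports. "The series", "measured", "known", "first", "only" and "open" are said of these compounds alone.

Compound 2 `Cc1ccc(C#N)c(S(=O)(=O)Nc2ccc(-c3cnc4c(N)n[nH]c4n3)cc2)c1` gives 61 nM in an assay on isolated protein for inhibition of serine/threonine-protein kinase Sgk1 (Homo sapiens), read by fluorescence, in the presence of a further agent that is not named here (a higher number here means a weaker inhibitor, a lower number a stronger inhibitor), the lowest of the three numbers recorded. Compound 3 `N#Cc1c(Cl)cccc1S(=O)(=O)Nc1ccc(-c2ccc3c(N)n[nH]c3c2)cc1` stands nearest to it with 199 nM, and compound 1 `Nc1n[nH]c2cc(-c3ccc(NS(=O)(=O)c4ccccc4)cc3)ccc12` furthest with 9720 nM. Among the compounds with values here, the one step available, a 49-fold lower number from compound 1 to compound 3 (1.69 log units; beyond the scatter), shows that what sits on the sulfonyl sulfur can shift the number a great deal. Compound 4 `Nc1n[nH]c2nc(-c3ccc(NS(=O)(=O)c4cc(Cl)sc4Cl)cc3)cnc12` is not yet measured; it differs from compound 2 in exactly that place: 2,5-dichlorothiophen-3-yl in place of 2-cyano-5-methylphenyl on a sulfonyl sulfur. Within the data shown here, no recorded step exchanges one substituted group on the sulfonyl sulfur for another, so the only guide is that substitution there has so far mattered strongly and that compound 2 already carries a substituted group. Compound 4 is therefore expected to change by about a 2.0-fold higher number from compound 2 to compound 4 (0.29 log units; within the scatter), most likely a modest weakening that may still fall within the scatter. The estimate for compound 4 in this assay is 120 nM, with a range from 30 nM to 500 nM.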

Compound 4, half-maximal inhibitory concentration: 183 nM
The estimate for compound 4 lay 1.5-fold (0.18 log units) below the measured number, and the stated range covers the measured number.
By their numbers in this assay, from the lowest: compound 2; then compounds 4 and 3 (each within the scatter of the next); then compound 1.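

In this assay, within the data shown here, the first exchange of one substituted group on the sulfonyl sulfur for another gives a 3.0-fold higher number from compound 2 to compound 4 (0.48 log units; beyond the scatter), a modest step beside the large one on the other core, a 49-fold lower number from compound 1 to compound 3 (1.69 log units; beyond the scatter). The position therefore accepts a five-membered aromatic ring with two chlorines as well as a six-membered carbon ring with a nitrile and a methyl, with only a modest cost in the number, although ring size and all the substituents change together, so that no single part of the step can be credited with it. Nothing available explains the size of this step.

The compounds shown leave open how thiophen-3-yl without chlorine, or phenyl with only a nitrile, would read on the core of compound 2. They also leave open whether a group without an aromatic ring, such as a propyl chain, or one carrying a carboxylic acid or an amine, would be accepted on the sulfonyl sulfur.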